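Methyl to Fluoro in a Weakly Active Pair

The source may hold more compounds than are shown below. What is called first, only, known or untested is meant among the compounds shown, and "the series" means these compounds.

Compound 1 `COC(=O)c1c(Nc2ccc(F)cc2)sc(C(=O)c2ccc(OC)cc2)c1C` and compound 2 `COC(=O)c1c(Nc2ccc(C)cc2)sc(C(=O)c2ccc(C)cc2)c1C` share one core. In a functional assay, with a stated time of 150 min, tested at 15 ug/mL (on this read-out lower numbers stand for a weaker effect and higher numbers for a stronger effect at the one concentration tested), compound 1 gives 15.2%, while compound 2 is reported as "not active" (no number reported), so no number marks where it stands. Compound 3 `COC(=O)c1c(Nc2ccc(F)cc2)sc(C(=O)c2ccc(C)cc2)c1C` differs from compound 2 by a single change: fluoro in place of methyl on an aromatic carbon. Compound 1 carries the same fluoro group yet reaches only 15.2%, so the step from compound 2 to compound 3 in this assay is expected to be small, at best a slight rise that stays within the usual scatter. Compound 3 is therefore estimated at 8%, within 0% to 20%.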

Compound 3, a percentage reported as activity, at one concentration (the size of the read-out at that concentration, not a potency): "not active" (no number reported)
Nothing numeric was reported for compound 3, so the estimate cannot be set against anything.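

Within the data shown here, compound 2 and compound 3 are both reported as "not active" in this assay, so no step between them can be read. As far as these compounds go, what sets compound 1 apart from them stays open, and no further data bear on this result.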